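Chain lengthening on a trimethoxybenzyl purine series

A few compounds are considered here, and "the series" means these few. Any claim that something is new, unique, unknown or untested is made for them only; others in the source may bear on it.

Measured compounds:
compound 1, `COc1cc(Cc2nc3c(N)ncnc3n2CCCO)cc(OC)c1OC`, gives 92700000 nM in a functional assay on MCF7 cells (Homo sapiens) for cytotoxicity; a lower number here means that less compound is needed, a higher number that more compound is needed for the effect
compound 2, `COc1cc(Cc2nc3c(N)ncnc3n2CC(C)CO)cc(OC)c1OC`, gives 49100000 nM in this assay
compound 3, `CCCCCn1c(Cc2cc(OC)c(OC)c(OC)c2)nc2c(N)nc(F)nc21`, gives 286000000 nM in this assay

Compound 1 and compound 2 share a core and differ by methyl in place of hydrogen on a saturated chain carbon bound to two saturated chain carbons. The step is a 1.9-fold lower number from compound 1 to compound 2 (0.28 log units; within the scatter), so the two values cannot be ordered. Compound 3 carries a different core; how it differs from compound 1 is not broken down here. Its number in this assay is the highest of the three, and its steps to compound 1 and to compound 2 both lie beyond the scatter.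

Compound 4, `CCCCCCn1c(Cc2cc(OC)c(OC)c(OC)c2)nc2c(N)nc(F)nc21`, is not yet measured. It differs from compound 3 by methyl in place of hydrogen on a saturated chain carbon, five bonds along the chain from an aromatic nitrogen. This is the same kind of change as that from compound 1 to compound 2, a methyl entering for a hydrogen, but the place is not the same: in the earlier pair the carbon is bound to two saturated chain carbons, whereas here it sits five bonds along the chain from an aromatic nitrogen, extending the chain by one carbon. Among the compounds with values here, the only precedent for this kind of change is a 1.9-fold lower number from compound 1 to compound 2 (0.28 log units; within the scatter), which stayed within the scatter, so the step expected from compound 3 to compound 4 in this assay is a 1.4-fold lower number from compound 3 to compound 4 (0.16 log units; within the scatter), a small one, because a 1.9-fold lower number from compound 1 to compound 2 (0.28 log units; within the scatter) gives no reason to expect more. Compound 4 is therefore estimated at 200000000 nM, with a range from 70000000 nM to 500000000 nM.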

Compound 4, half-maximal effective concentration: 112000000 nM
Compound 4: the middle estimate sits 1.8-fold (0.25 log units) above what was measured; measured number inside the range.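

In this assay, the methyl entering for a hydrogen on a saturated chain carbon, five bonds along the chain from an aromatic nitrogen, gives a 2.6-fold lower number from compound 3 to compound 4 (0.41 log units; beyond the scatter). Set beside the earlier methyl step on the other core, the size of this step cannot be told apart from it: the same change on two cores in this assay, a 1.9-fold lower number (0.28 log units; within the scatter) from compound 1 to compound 2 and a 2.6-fold lower number (0.41 log units; beyond the scatter) from compound 3 to compound 4, 1.4-fold (0.13 log units) apart, within the scatter of two such steps. This shows only that, across these two pairs, the size of the step does not differ measurably between the two cores; it does not show a transferable effect, since one step lies within the scatter and the other beyond it, the methyl enters at a different place in each pair, and the cores also differ in other respects, so two pairs support no general rule for the series.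

The compounds shown leave open whether a longer chain on the core of compound 3 would extend the step seen here or leave the number unchanged, and whether a methyl at one and the same place on both cores would give steps of matching size. They also leave open how an amine or a carboxylic acid in place of the hydroxyl of compound 1 would read in this assay.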